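A few compounds are considered here, and "the series" means these few. Any claim that something is new, unique, unknown or untested is made for them only; others in the source may bear on it.

Measured compounds:
Compound 1, `O=C(Nc1cc(Sc2ncn[nH]2)c(O)c2ccccc12)c1cccc([N+](=O)[O-])c1`, 48000 nM.
Compound 2, `O=C(Nc1cc(Sc2ncn[nH]2)c(O)c2ccccc12)c1ccc(Cl)cc1`, 25700 nM.

Both compounds share one core and differ only in the aromatic ring attached to the carbonyl carbon of the amide. In a functional assay on MDA-MB-231 cells (Homo sapiens) for antiproliferative activity, read by MTT assay, with a stated time of 48 h (on this read-out lower numbers stand for stronger inhibition and higher numbers for weaker inhibition), compound 1 gives 48000 nM and compound 2 gives 25700 nM. Among the measured compounds shown here, the one step that exists between them, a 1.9-fold lower number from compound 1 to compound 2 (0.27 log units; within the scatter), is within the scatter, so the two numbers cannot be told apart with confidence, and compound 2 holds the lower of the two numbers only in a nominal sense.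

Compound 3, `COc1cccc(C(=O)Nc2cc(Sc3ncn[nH]3)c(O)c3ccccc23)c1`, has not yet been measured. Its difference from compound 2 is 3-methoxyphenyl in place of 4-chlorophenyl on a carbonyl carbon. For the measured compounds named here, the only measured step that bears on this change is the step from compound 1 to compound 2, which swapped one ring substituent for another at the same position and moved the number by less than the scatter. On that basis the expected step in this assay, a 1.2-fold higher number from compound 2 to compound 3 (0.07 log units; within the scatter), is none beyond the scatter. Compound 3 is therefore expected to give about 30000 nM, within a range of 12000 nM to 80000 nM.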

Compound 3, half-maximal inhibitory concentration: > 100000 nM
Compound 3: a limit, no number; the forecaster's own chance of this, stated with the estimate: 15%; middle value at least 3.3-fold (0.52 log units) from the limit.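

In this assay compound 3 gives a limit of the assay and not a number: the limit of > 100000 nM in this assay, at which 1 of the 3 values shown sits.

This shows that the aromatic ring on the carbonyl carbon is not a place where every swap leaves the read-out unchanged: the earlier change, a 1.9-fold lower number from compound 1 to compound 2 (0.27 log units; within the scatter), could not be told from noise, whereas the new one, an at least 3.8-fold higher number from compound 2 to compound 3 (0.59 log units; beyond the scatter), can. The comparison with the nitro compound points the same way, since methoxy in place of nitro on an aromatic carbon gives an at least 2.0-fold higher number from compound 1 to compound 3 (0.31 log units; beyond the scatter), so among these three compounds the only steps beyond the scatter are the two that end at compound 3.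

With so few compounds, the data cannot say whether the loss of inhibition belongs to the methoxy group itself or to the 3-methoxyphenyl arrangement as a whole, as compound 3 differs from compound 2 in both the group carried and the name of the ring. As far as these compounds go, whether a ring bearing an amine or a carboxylic acid would stay close to compound 1 and compound 2 or behave like compound 3 also remains open.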